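This account rests on a few compounds, and the source may have more. Where it says the series, first, only, none or still open, it means among the compounds named here.

Measured compounds in an ADME assay on HEL cells (Homo sapiens) for cytotoxicity; on this read-out higher numbers stand for lower toxicity in this test and lower numbers for higher toxicity in this test:
- compound 1, `Cc1ccc(OCCCCCn2ccc(=O)[nH]c2=O)cc1`: > 100000 nM
- compound 2, `Cc1cc(C)cc(OCCCCCn2ccc(=O)[nH]c2=O)c1`: > 100000 nM
- compound 3, `Cc1cn(CCCCCOc2ccc(Br)cc2)c(=O)[nH]c1=O`: > 100000 nM

In this assay compound 1 gives > 100000 nM, which is a limit of the assay and not a number. Compound 2 gives > 100000 nM, also a limit. Compound 3 gives > 100000 nM, again a limit. Among the compounds with values here, every value shown sits at the limit of > 100000 nM in this assay, at which 3 of the 3 values shown sit, so compound 1 stands where the whole series stands, and no step between measured compounds can be read.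

Compound 4 `Nc1ccc(OCCCCCn2ccc(=O)[nH]c2=O)cc1` differs from compound 1 by amino in place of methyl on an aromatic carbon. No step beyond the scatter is expected in this assay, in either direction. The estimated step is a step that the limit leaves unreadable from compound 1 to compound 4. Compound 4 is expected at 150000 nM, within 50000 nM to 500000 nM, most likely reported again as a limit.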

Compound 4, half-maximal cytotoxic concentration: > 100000 nM
Compound 4 ended at the assay's limit; the forecaster's own chance of this, stated with the estimate: 85%; the middle value does not contradict the limit.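

No step can be read from compound 1 to compound 4, because both values are limits: the limit of > 100000 nM in this assay, at which 4 of the 4 values shown sit. The compounds shown leave open how far the half-maximal cytotoxic concentration of any of them lies beyond that limit.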